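Replacing Piperidin-1-yl with Dimethylamino in Compound 4

The source may hold more compounds than are shown below. What is called first, only, known or untested is meant among the compounds shown, and "the series" means these compounds.

Of the compounds shown here, three have been measured in an assay on Sf9 cells for inhibition of protein deacetylase HDAC6 (Homo sapiens), read by fluorescence, with a stated time of 90 min; a higher number here means a weaker inhibitor, a lower number a stronger inhibitor. Compound 1, `CNC(=O)CN(Cc1ccc(C(=O)NO)cc1)C(=O)c1ccc(C(C)C)cc1`, gives 60 nM, and compound 2, `CC(C)c1ccc(C(=O)N(Cc2ccc(C(=O)NO)cc2)C(C)(C)C(=O)NCc2ccccc2)cc1`, gives 60 nM. Going by the values given here, compound 3, `Cc1cc(C)cc(C(=O)N(CC(=O)N2CCCCC2)Cc2ccc(C(=O)NO)cc2)c1`, gives 130 nM; this is the highest of the three numbers, and the gap from compound 3 to each of the other two lies beyond the usual scatter, so compound 3 is the weakest inhibitor of the three measured so far.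

Compound 4, `Cc1cc(C)cc(C(=O)N(CC(=O)N(C)C)Cc2ccc(C(=O)NO)cc2)c1`, has not yet been measured. It differs from compound 3 in one place: dimethylamino in place of piperidin-1-yl on a carbonyl carbon. The shared core and all remaining groups stay as they are in compound 3.

Among the compounds with values here, no step between two measured compounds mirrors this exchange, so the measured set gives no direct guide to how the number should move. The smaller group replaces a ring at the far end of the side amide while the rest of the molecule is unchanged, and on that basis the expectation is a step of little size, in either direction, or none beyond the scatter. The estimate for compound 4 is 150 nM, with a range from 60 nM to 350 nM. This expected outcome corresponds to a step of a 1.2-fold higher number from compound 3 to compound 4 (0.06 log units; within the scatter).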

Compound 4, half-maximal inhibitory concentration: 230 nM
For compound 4 the middle estimate is 1.5-fold (0.19 log units) below the measured one, and the stated range covers the measured number.
By their numbers in this assay, from the lowest: compounds 1 and 2 (each within the scatter of the next); then compounds 3 and 4 (each within the scatter of the next).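

Going by these compounds alone, this is the first exchange in the set made in one place only, and in this assay it gives a 1.8-fold higher number from compound 3 to compound 4 (0.25 log units; within the scatter). On this carbonyl carbon, whose other neighbour is a saturated chain carbon, the six-membered non-aromatic ring of piperidin-1-yl, with 6 heavy atoms, can therefore be replaced by dimethylamino, with 3 heavy atoms and no ring, without a step that stands clear of the scatter, at least with the rest of compound 3 held constant. No measurement is at hand that would explain this outcome.

What the compounds shown leave open is whether any other group on this carbonyl carbon, such as morpholin-4-yl, pyrrolidin-1-yl or a longer chain on the amide nitrogen, would produce a step beyond the scatter. Going by these compounds, it is also open whether the exchange of piperidin-1-yl for dimethylamino would read the same way with an isopropyl group in place of the two methyl groups of compound 3, since this single pair cannot speak for other substituents.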